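Cyclobutyl carboxamide in place of hydroxycyclohexyl on the pyridine core

The source may hold more compounds than are shown below. What is called first, only, known or untested is meant among the compounds shown, and "the series" means these compounds.

Measured so far:
compound 1 `N#Cc1cnc(NCc2cnccc2C(F)(F)F)cc1N[C@H]1CC[C@H](O)CC1`, 350 nM
compound 2 `CC1(C)C[C@H](Nc2nc(NCc3cnccc3C(F)(F)F)ncc2C#N)CC[C@@H]1O`, 6 nM

In an assay on isolated protein for inhibition of protein kinase C theta type (Homo sapiens), read by TR-FRET, with a stated time of 2 h (on this read-out higher numbers stand for weaker inhibition and lower numbers for stronger inhibition), compound 1 gives 350 nM, the highest of the two numbers shown; compound 2 gives 6 nM, a much lower number, but the two share no single change that can be read as a step. Compound 3 `CC1(C)[C@@H](C(N)=O)C[C@H]1Nc1cc(NCc2cnccc2C(F)(F)F)ncc1C#N` differs from compound 1 by 3-carbamoyl-2,2-dimethylcyclobutyl in place of 4-hydroxycyclohexyl on a nitrogen on an aromatic ring. Going by the values given here, no measured step speaks directly to this change, so the expectation is a moderate move toward a lower number, within uncertainty wide enough to include no change. Compound 3 is expected at 120 nM, between 25 nM and 600 nM, which means an estimated step of a 2.9-fold lower number from compound 1 to compound 3 (0.46 log units; beyond the scatter).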

Compound 3, half-maximal inhibitory concentration: 1.4 nM
Estimate against measurement, compound 3: 86-fold (1.93 log units) above; measured number below the stated range.
By their numbers in this assay, from the lowest: compound 3; then compound 2; then compound 1.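

In this assay, the group on this nitrogen proves decisive for the number: 3-carbamoyl-2,2-dimethylcyclobutyl in place of 4-hydroxycyclohexyl gives a 250-fold lower number from compound 1 to compound 3 (2.40 log units; beyond the scatter) on the shared core. The hydrogen-bond donor and acceptor counts of the two groups are the same, so those counts do not separate them. No measurement at hand accounts for the size of this step. The step changes the ring, the gem-dimethyl groups and the carbamoyl together, and the compounds shown do not separate these. On these data alone, whether a carboxylic acid or an amine in place of the carbamoyl would keep the low number remains open.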